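The source may hold more compounds than are shown below. What is called first, only, known or untested is meant among the compounds shown, and "the series" means these compounds.

Measured so far in a functional assay on HOS cells (Homo sapiens) for inhibition, with a stated time of 72 h; a lower number here means a stronger inhibitor, a higher number a weaker inhibitor:

compound 1 `NC1CCC(Nc2nc(NCc3ccc(-c4ccccc4)cc3)c3ncn(C4CCCC4)c3n2)CC1`, 290 nM
compound 2 `NC1CCC(Nc2nc(NCc3ccc(-c4cccc(F)c4)cc3)c3ncn(C4CCCC4)c3n2)CC1`, 211 nM
compound 3 `NC1CCC(Nc2nc(NCc3ccc(-c4ccccc4)nc3)c3ncn(C4CCCC4)c3n2)CC1`, 206 nM

Compound 2 differs from compound 1 in one place, (fluoro in place of hydrogen on an aromatic carbon), and this change gave a 1.4-fold lower number from compound 1 to compound 2 (0.14 log units; within the scatter). Compound 3 stands on a different core; the difference between the two cores is 6-phenylpyridin-3-yl in place of 4-phenylphenyl on a saturated chain carbon bound to a nitrogen on an aromatic ring, and that change gave a 1.4-fold lower number from compound 1 to compound 3 (0.15 log units; within the scatter). Compound 2 and compound 3 thus sit close together, and neither is separated from compound 1 by more than the usual scatter.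

Compound 4 `NC1CCC(Nc2nc(NCc3ccc(-c4cccc(F)c4)nc3)c3ncn(C4CCCC4)c3n2)CC1` has not yet been measured. Within the data shown here, it differs from compound 3 by fluoro in place of hydrogen on an aromatic carbon, which is the same change as the one from compound 1 to compound 2, now made on the core of compound 3. Among the measured compounds shown here, the only guide is that earlier step, which rests on a single pair. Because a 1.4-fold lower number from compound 1 to compound 2 (0.14 log units; within the scatter) barely moved the number, compound 4 is expected to land near compound 3 in this assay, with a step of about a 1.3-fold lower number from compound 3 to compound 4 (0.11 log units; within the scatter). The estimate for compound 4 is therefore 160 nM, within a range from 70 nM to 360 nM.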

Compound 4, half-maximal inhibitory concentration: 44 nM
Compound 4: the middle estimate sits 3.6-fold (0.56 log units) above what was measured; the whole stated range lies above it.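

On the core of compound 3, the change from phenyl to 3-fluorophenyl gave a 4.7-fold lower number from compound 3 to compound 4 (0.67 log units; beyond the scatter) in this assay. Set beside the earlier step, the same change did not carry over at one size from one core to the other: the same change on two cores in this assay, a 1.4-fold lower number (0.14 log units; within the scatter) from compound 1 to compound 2 and a 4.7-fold lower number (0.67 log units; beyond the scatter) from compound 3 to compound 4, 3.4-fold (0.53 log units) apart, beyond the scatter of two such steps. Among these compounds, this shows that the size of the step depends on the core that carries it, here the one with the 6-phenylpyridin-3-yl group against the one with the 4-phenylphenyl group, but with a single pair on each core it does not show why the two steps differ or what the step would be on any further core.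

The compounds shown leave open whether the larger step belongs to fluoro alone, or whether chloro, methyl or methoxy in the same place on the core of compound 3 would give a step of like size. They also leave open what 2-fluorophenyl or 4-fluorophenyl would give on either core.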